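Replacing vinyl with 2-(4-methoxyphenyl)ethenyl on the shared core

The compounds below may be only part of what the source reports. "The series", "measured", "known", "first", "only" and "open" are said of these compounds alone.

In a functional assay on HeLa cells (Homo sapiens) for cytotoxicity, read by WST assay, with a stated time of 48 h (a higher number here means a weaker inhibitor, a lower number a stronger inhibitor), compound 1 (`O[C@@H](c1ccccc1)[C@H]1CO[C@H](c2ccccc2)[C@@H](C/C=C/c2ccccc2)C1`) gives 6060 nM as its value. Among the compounds with values here, compound 2 (`C=CC[C@H]1C[C@@H]([C@@H](O)c2ccccc2)CO[C@@H]1c1ccccc1`) gives 25400 nM as the higher of the two numbers so far. Compound 3 (`COc1ccc(/C=C/C[C@H]2C[C@@H]([C@@H](O)c3ccccc3)CO[C@@H]2c2ccccc2)cc1`) has not yet been measured, and its difference from compound 2 is as follows (2-(4-methoxyphenyl)ethenyl in place of vinyl on a saturated chain carbon bound to a saturated ring carbon). This is 2-(4-methoxyphenyl)ethenyl in place of vinyl on a saturated chain carbon bound to a saturated ring carbon. Within the data shown here, one measured step bears on this change, that of 2-phenylethenyl giving way to vinyl (a 4.2-fold higher number from compound 1 to compound 2 (0.62 log units; beyond the scatter)), a modest step beyond the scatter. Among the measured compounds shown here, no measured compound isolates the difference between 2-phenylethenyl and 2-(4-methoxyphenyl)ethenyl. A step of similar size in the opposite direction is therefore expected in this assay toward a lower number. The expected step is (a 3.9-fold lower number from compound 2 to compound 3 (0.59 log units; beyond the scatter)) for compound 3 on this reasoning. The estimated value for compound 3 is 6500 nM with an expected range from 2500 nM to 16000 nM in this read-out.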

Compound 3, half-maximal inhibitory concentration: 8300 nM
Estimate against measurement, compound 3: 1.3-fold (0.11 log units) below, and the stated range covers the measured number.
By their numbers in this assay, from the lowest: compounds 1 and 3 (each within the scatter of the next); then compound 2.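

In this assay, 2-(4-methoxyphenyl)ethenyl on the saturated chain carbon gives a lower number than vinyl (a 3.1-fold lower number from compound 2 to compound 3 (0.49 log units; beyond the scatter)), so a second aromatic ethenyl group now shows this difference from vinyl. Methoxy in place of hydrogen on an aromatic carbon makes no change that can be read (a 1.4-fold higher number from compound 1 to compound 3 (0.14 log units; within the scatter)), which places compounds 1 and 3 together, with neither compound going against the pattern in this small set. Nothing available here accounts for either step.

The compounds shown leave open whether an amine or a carboxylic acid in place of methoxy on that aromatic carbon would move the number beyond the scatter. They also leave open whether a saturated propyl group in place of vinyl would give a number nearer compound 2 or nearer compounds 1 and 3.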